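Swapping the aryl group on a thiosemicarbazone tail

This account rests on a few compounds, and the source may have more. Where it says the series, first, only, none or still open, it means among the compounds named here.

Compound 3 `CC1=CC[C@@H]([C@@](C)(O)CCCC(C)(C)NC(=S)N/N=C\c2cccc([N+](=O)[O-])c2)CC1` gives 14100 nM in a functional assay on HT-29 cells (Homo sapiens) for cytotoxicity, read by sulforhodamine B assay; a higher number here means a weaker inhibitor of growth, a lower number a stronger inhibitor of growth. Its number sits within the scatter of both its neighbours: compound 1 `CC1=CC[C@@H]([C@@](C)(O)CCCC(C)(C)NC(=S)N/N=C\c2ccccc2)CC1` gives 9960 nM and the step is a 1.4-fold higher number from compound 1 to compound 3 (0.15 log units; within the scatter), while compound 2 `CC1=CC[C@@H]([C@@](C)(O)CCCC(C)(C)NC(=S)N/N=C\c2ccc(N(C)C)cc2)CC1` gives 27700 nM and the step is a 2.0-fold lower number from compound 2 to compound 3 (0.29 log units; within the scatter). Compound 4 `CC1=CC[C@@H]([C@@](C)(O)CCCC(C)(C)NC(=S)N/N=C\c2ccccc2Cl)CC1` carries 2-chlorophenyl in place of 3-nitrophenyl on a carbon with a double bond to nitrogen. Within the data shown here, no measured step touches a chloro group; the only steps on this ring are a 2.8-fold higher number from compound 1 to compound 2 (0.44 log units; beyond the scatter) and a 1.4-fold higher number from compound 1 to compound 3 (0.15 log units; within the scatter), both small. Compound 4 is therefore expected to stay close to compound 3, with a step of a 1.3-fold lower number from compound 3 to compound 4 (0.11 log units; within the scatter) that need not exceed the scatter. Compound 4 is estimated at 11000 nM in this assay, within 4500 nM to 28000 nM.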

Compound 4, concentration for 50% growth inhibition: 23700 nM
Estimate against measurement, compound 4: 2.2-fold (0.33 log units) below, within the range that was stated.
By their numbers in this assay, from the lowest: compounds 1, 3, 4 and 2 (each within the scatter of the next, the first and the last beyond it).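

Chloro in place of hydrogen is the second change on this ring to go beyond the scatter (a 2.4-fold higher number from compound 1 to compound 4 (0.38 log units; beyond the scatter)), in the same direction as the dimethylamino change, though the nitro compound 3 goes against this pattern by staying within it. The 2-chlorophenyl group does not separate compound 4 from either other substituted compound (a 1.7-fold higher number from compound 3 to compound 4 (0.23 log units; within the scatter); a 1.2-fold lower number from compound 2 to compound 4 (0.07 log units; within the scatter)). No measurement shown accounts for these steps.

From the compounds shown here alone, whether a methoxy group, a fluoro group or a pyridine ring in place of the phenyl ring would give a lower number than compound 1 in this assay stays open.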